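This account rests on a few compounds, and the source may have more. Where it says the series, first, only, none or still open, it means among the compounds named here.

Measured so far:
compound 1, `Cc1ccc2nc(Nc3nc(Nc4ccc(S(C)(=O)=O)cc4)ncc3F)sc2c1`, > 50000 nM;
compound 2, `CS(=O)(=O)c1ccc(Nc2nccc(Nc3nc4ccc(F)cc4s3)n2)cc1`, 1940 nM.

Among the measured compounds shown here, in a functional assay on PC-3 cells (Homo sapiens) for antiproliferative activity, read by MTT assay, with a stated time of 48 h (a higher number here means a weaker inhibitor, a lower number a stronger inhibitor), compound 2 gives 1940 nM, and this is the only plain number among the two results. For compound 1 the result, > 50000 nM, is a limit of the assay and not a number, which is what the limit of > 50000 nM in this assay, at which 1 of the 2 values shown sits, records. Compound 3 is `CS(=O)(=O)c1ccc(Nc2ncc(F)c(Nc3nc4ccc(F)cc4s3)n2)cc1` and has not yet been measured. It differs from compound 2 in one place: fluoro in place of hydrogen on an aromatic carbon. For the measured compounds named here, no step between two measured compounds is available to gauge this change: compound 1 and compound 2 differ from each other in more than one place, and their two values show only that one sits at the limit while the other is a measurable number. In this assay the expected step of a 4.1-fold higher number from compound 2 to compound 3 (0.62 log units; beyond the scatter) is a weakening beyond the usual scatter. Compound 3 is therefore estimated at 8000 nM, within 2000 nM to 40000 nM.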

Compound 3, half-maximal inhibitory concentration: > 50000 nM
Compound 3 ended at the assay's limit; the forecaster's own chance of this, stated with the estimate: 25%; middle value at least 6.2-fold (0.79 log units) away from the limit.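

Among the compounds shown here, putting fluoro in place of hydrogen on the six-membered aromatic ring with 2 nitrogen gives the first readable step at this position: in this assay, the change produces an at least 25-fold higher number from compound 2 to compound 3 (1.41 log units; beyond the scatter), so one added fluorine is enough to lose measurable activity. As far as these compounds go, compound 3 gives > 50000 nM, which is a limit of the assay and not a number, so the true size of the step stays open: the limit of > 50000 nM in this assay, at which 2 of the 3 values shown sit. The step between the other pair, compound 1 and compound 3, cannot be read, as both values are limits.

The compounds shown compare only hydrogen and fluoro at this position, leaving open how a chloro, a methoxy or an amine there would behave. They also leave open how far above the limit compound 3 lies.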